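Notes on compound 3: phenyl for cyclopropyl

The source may report more compounds than this note shows. Statements on the series, on what has been measured and on what is new or still open speak of the compounds shown alone.

Two compounds of the series have numbers in an ADME assay on microsomes from liver (Homo sapiens) for metabolic stability; a higher number here means that the compound lasts longer, a lower number that the compound disappears faster. Compound 1 `CC(C)[C@H](C[C@H]1OC(=O)NC1=O)c1ccc(-c2ccc3cccc(F)c3c2)[nH]c1=O` gives 1.68 h in this assay. Compound 2 `O=C1NC(=O)/C(=C/C(c2ccc(-c3ccc4cccc(F)c4c3)[nH]c2=O)C2CC2)O1` gives 1.98 h in this assay, the higher of the two numbers, though its gap to compound 1 lies within the scatter, so the two read as alike. Compound 3 `O=C1NC(=O)/C(=C/C(c2ccccc2)c2ccc(-c3ccc4cccc(F)c4c3)[nH]c2=O)O1` has not been measured yet. It differs from compound 2 in one place: phenyl in place of cyclopropyl on a saturated chain carbon bound to an aromatic carbon and a double-bonded chain carbon. Going by the values given here, no measured pair shows this change, so the data give no guide to its size; the working assumption is a modest loss that may well stay within the scatter. The expected step of a 1.4-fold lower number from compound 2 to compound 3 (0.15 log units; within the scatter) is therefore small and downward. For compound 3 the estimated number in this assay is 1.4 h, with a range from 0.7 h to 3 h.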

Compound 3, half-life in the Homo sapiens assay: 2.1 h
For compound 3 the middle estimate is 1.5-fold (0.18 log units) below the measured one; the measured number falls inside the stated range.
By their numbers in the Homo sapiens assay, from the lowest: compounds 1, 2 and 3 (each within the scatter of the next).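

On a saturated chain carbon bound to an aromatic carbon and a double-bonded chain carbon, phenyl and cyclopropyl read as alike in the Homo sapiens assay, with a 1.1-fold higher number from compound 2 to compound 3 (0.03 log units; within the scatter). Going by these compounds alone, this is the first one-place comparison, and it shows that this carbon can carry an aromatic ring in place of a three-membered one with no reading beyond the scatter in that assay. In a physicochemical assay for solubility, measured as kinetic solubility, at pH 2 (on this read-out lower numbers stand for lower solubility and higher numbers for higher solubility), compound 2 gives 3850 nM and compound 3 gives 15400 nM, so the pair does separate on this second read-out, whereas in the Homo sapiens assay it does not.

From the compounds shown here alone, whether the same holds for a different group on this carbon, such as a primary amine or a carboxylic acid, stays open. Within the data shown here, with only one pair, the size of the physicochemical assay step cannot be extended beyond compound 2 and compound 3.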